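Fluoro for Methyl on a Thioether Hydroxamate

This account rests on a few compounds, and the source may have more. Where it says the series, first, only, none or still open, it means among the compounds named here.

Measured so far in an assay on isolated protein for inhibition of matrix metalloproteinase-9 (Homo sapiens); on this read-out lower numbers stand for stronger inhibition and higher numbers for weaker inhibition:
Compound 1, `Cc1ccc(Oc2ccc(N(CC(=O)NO)S(C)(=O)=O)cc2)cc1`, gives 31 nM.
Compound 2, `Cc1ccc(Sc2ccc(N(C[C@H](O)C(=O)NO)S(C)(=O)=O)cc2)cc1`, gives 54 nM.

Compound 2 has the higher of the two numbers, but its gap to compound 1 lies within the scatter, so on these data the two compounds cannot be told apart.

Compound 3, `CS(=O)(=O)N(C[C@H](O)C(=O)NO)c1ccc(Sc2ccc(F)cc2)cc1`, keeps the core of compound 2 and alters one group: fluoro in place of methyl on an aromatic carbon. Within the data shown here, no measured pair in this set shows this exchange, so nothing here points to a shift in either direction. In this assay no step beyond the scatter is expected, a 1.1-fold higher number from compound 2 to compound 3 (0.05 log units; within the scatter). The number for compound 3 is therefore expected to sit close to that of compound 2, and the estimate for compound 3 in this assay is 60 nM, with a range from 25 nM to 150 nM.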

Compound 3, half-maximal inhibitory concentration: 104 nM
Beside the measured number, compound 3's estimate is 1.7-fold (0.24 log units) below it; low and high end bracket the measured number.
By their numbers in this assay, from the lowest: compounds 1, 2 and 3 (each within the scatter of the next, the first and the last beyond it).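

Among these compounds, this is the first measured pair that changes only the group on this aromatic carbon, para to a large group, and fluoro in place of methyl gives (a 1.9-fold higher number from compound 2 to compound 3 (0.28 log units; within the scatter)) in this assay. The 4-methylphenyl and 4-fluorophenyl versions of the thioether therefore cannot be told apart on these data, so this one position accepts either group without a change that can be read beyond ordinary repeat variation. Nothing available explains why the two numbers fall where they do.

The compounds shown contain only methyl and fluoro at this position, so a single exchange cannot show how far the tolerance extends. On these data alone, how a chloro, a methoxy, an amine or a carboxylic acid would behave on the same carbon remains open.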